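The source may report more compounds than this note shows. Statements on the series, on what has been measured and on what is new or still open speak of the compounds shown alone.

Compound 1 has the structure `CC(=O)O[C@@H]1OC(=O)[C@](C)(C(C)=O)[C@@H]1C`. Within the data shown here, in a functional assay on HT-29 cells (Homo sapiens) for cytotoxicity, read by MTT assay (on this read-out lower numbers stand for stronger inhibition and higher numbers for weaker inhibition), compound 1 gives 5000 nM, the second highest of the three numbers measured so far. Compound 2, with the structure `CC(=O)O[C@@H]1OC(=O)[C@](C)(C(=O)CBr)[C@@H]1C`, gives 6000 nM, and compound 3, with the structure `CC(=O)[C@@]1(C)C(=O)O[C@@H](OC(=O)C(C)(C)C)[C@H]1C`, gives 2000 nM. The two measured steps from compound 1 both alter the side chain rather than the ring: a 1.2-fold higher number from compound 1 to compound 2 (0.08 log units; within the scatter) and a 2.5-fold lower number from compound 1 to compound 3 (0.40 log units; beyond the scatter).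

Compound 4 has the structure `CC(=O)O[C@@H]1OC(=O)[C@@H](C(C)=O)[C@@H]1C`. It differs from compound 1 by hydrogen in place of methyl on a saturated ring carbon. Among the measured compounds shown here, neither measured step touches this ring carbon, so no step bears directly on the change; both sit elsewhere, and the only step beyond the scatter, from compound 1 to compound 3, concerns the ester group. Without a comparable step, the expectation is a number close to that of compound 1, with no change beyond the scatter. The estimated step is therefore no change at the digits printed from compound 1 to compound 4 (within the scatter). For compound 4 in this assay a value of about 5000 nM is expected, with a range from 2000 nM to 12500 nM.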

Compound 4, half-maximal inhibitory concentration: > 50000 nM
Compound 4 was reported as a limit (the forecaster's own chance of this, stated with the estimate: 15%); middle value at least 10-fold (1.00 log units) from the limit.
By their numbers in this assay, from the lowest: compound 3; then compounds 1 and 2 (each within the scatter of the next). At a limit, above all of these: compound 4.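

Hydrogen in place of methyl on this saturated ring carbon gives an at least 10-fold higher number from compound 1 to compound 4 (1.00 log units; beyond the scatter), so this ring position matters in a way the earlier compounds could not show. In this assay compound 4 stands at a limit, > 50000 nM, and not at a number. The methyl group here therefore counts for more in this assay than the bromo change in compound 2 or the tert-butyl change in compound 3, while the full size of the loss stays unknown: the limit of > 50000 nM in this assay, at which 1 of the 4 values shown sits.

The compounds shown cannot tell whether methyl itself is needed here, or whether an ethyl group, a longer chain or a fluorine atom on this ring carbon would keep the number of compound 1 or lower it. They also leave open whether the same change would cost as much with the tert-butyl group of compound 3 in place.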